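This account rests on a few compounds, and the source may have more. Where it says the series, first, only, none or still open, it means among the compounds named here.

Measured so far in an assay on isolated protein for inhibition of Indoleamine 2,3-dioxygenase 2 (Homo sapiens); on this read-out higher numbers stand for weaker inhibition and lower numbers for stronger inhibition:
compound 1 `CCCCc1cn(CCNc2nonc2/C(=N/O)Nc2ccc(F)c(Br)c2)nn1`: 830 nM
compound 2 `CC(C)(C)c1cn(CCNc2nonc2/C(=N/O)Nc2ccc(F)c(Br)c2)nn1`: 1870 nM

Compound 1 holds the lower of the two numbers; compound 2 sits at a 2.3-fold higher number from compound 1 to compound 2 (0.35 log units; beyond the scatter). Compound 3 `OCCOCc1cn(CCNc2nonc2/C(=N/O)Nc2ccc(F)c(Br)c2)nn1` differs from compound 1 by 2-hydroxyethoxy in place of propyl on a saturated chain carbon bound to an aromatic carbon. Within the data shown here, the single measured step, a 2.3-fold higher number from compound 1 to compound 2 (0.35 log units; beyond the scatter), exchanges one alkyl for another and so bears only loosely on a change of this different kind; it shows that a small change at the place of the change moves this assay modestly. The expected step for compound 3 is therefore modest, direction uncertain, a 1.4-fold higher number from compound 1 to compound 3 (0.16 log units; within the scatter). Compound 3 is estimated at 1200 nM, range 450 nM to 3200 nM.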

Compound 3, half-maximal inhibitory concentration: 144 nM
Compound 3: the middle estimate sits 8.3-fold (0.92 log units) above what was measured; measured number below the stated range.
By their numbers in this assay, from the lowest: compound 3; then compound 1; then compound 2.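

At this place in this assay the substituent need not be an alkyl group: the change from butyl to (2-hydroxyethoxy)methyl brings a 5.8-fold lower number from compound 1 to compound 3 (0.76 log units; beyond the scatter) and the change from tert-butyl brings a 13-fold lower number from compound 2 to compound 3 (1.11 log units; beyond the scatter) as well. The entering chain carries oxygen atoms, a hydrogen-bond donor and hydrogen-bond acceptors, none of which the alkyl groups have, so this place responds to more than the alkyl swap suggested. No evidence at hand accounts for the drop.

Going by these compounds, whether the hydroxyl, the ether oxygen or the chain as a whole carries the step remains open. A methyl ether of the same chain, an amine or a carboxylic acid would help separate these.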